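The source may hold more compounds than are shown below. What is called first, only, known or untested is meant among the compounds shown, and "the series" means these compounds.

Series notes. Compound 1 `COc1cccc(CNCCCNc2ccnc3cc(Oc4ccc(Cl)cc4)ccc23)c1O` is the reference point. In an ADME assay for permeability, using PAMPA, with a stated time of 30 min, at pH 7.4 (on this read-out lower numbers stand for lower permeability and higher numbers for higher permeability), compound 1 gives 317 10^-6 cm/s, the highest of the three numbers in hand; compound 3 `COc1cccc(CNCCCNc2ccnc3cc(-c4cc(C(F)(F)F)cc(C(F)(F)F)c4)ccc23)c1O` gives 237 10^-6 cm/s, and the gap between these two lies within the scatter, so no order is claimed between them. Compound 2 `COc1ccc(F)cc1CNCCCNc1ccnc2cc(CC(C)C)ccc12` gives 23 10^-6 cm/s, a gap from compound 1 that is beyond the scatter. Compound 4 `COc1cccc(CNCCCNc2ccnc3cc(-c4cccc5ccccc45)ccc23)c1O` has not been measured. Its change from compound 1: naphthalen-1-yl in place of 4-chlorophenoxy on an aromatic carbon. Going by the values given here, no measured pair shows this step directly. Because compound 3, which also carries an aromatic ring in place of the ether, gives 237 10^-6 cm/s, the expected step in this assay is a 1.3-fold lower number from compound 1 to compound 4 (0.10 log units; within the scatter), not beyond the scatter. Compound 4 is expected at 250 10^-6 cm/s, between 120 10^-6 cm/s and 450 10^-6 cm/s.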

Compound 4, apparent permeability: 237 10^-6 cm/s
For compound 4 the middle estimate is 1.1-fold (0.02 log units) above the measured one, and the stated range covers the measured number.
By their numbers in this assay, from the lowest: compound 2; then compounds 3, 4 and 1 (each within the scatter of the next).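

In this assay, going by these compounds alone, the first single-place step, naphthalen-1-yl in place of 4-chlorophenoxy, gives a 1.3-fold lower number from compound 1 to compound 4 (0.13 log units; within the scatter) and so stays within the scatter. At this aromatic carbon, therefore, the ether oxygen and the chlorine can both leave without a readable shift, at least when a carbon-only fused aromatic group enters. This holds for this one pair only.

From the compounds shown here alone, whether an amine or a carboxylic acid at this same carbon would hold the read-out remains open. Nothing measured bears on why these two groups read alike.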